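Flipping Two Ring Stereocentres in a Phosphoserine Lipid Ester

This account rests on a few compounds, and the source may have more. Where it says the series, first, only, none or still open, it means among the compounds named here.

Compound 1 `CCCCCCCCCCCOc1ccccc1CCC(=O)O[C@H]1COCC[C@H]1OP(=O)(O)OC[C@H](N)C(=O)O` and compound 2 `CCCCCCCCCCCOc1ccccc1CCC(=O)O[C@@H]1COCC[C@H]1OP(=O)(O)OC[C@H](N)C(=O)O` share every atom and bond and differ only in how one saturated ring carbon is drawn. In an assay on HEK293 cells for agonist activity at putative P2Y purinoceptor 10 (Mus musculus), with a stated time of 1 h (on this read-out higher numbers stand for larger maximal responses and lower numbers for smaller maximal responses), compound 1 gives 8.6% and compound 2 gives 11.4%, the higher of the two numbers, though the step of a number 2.8 percentage points higher from compound 1 to compound 2 (within the scatter) does not rise above the usual scatter. Compound 3 `CCCCCCCCCCCOc1ccccc1CCC(=O)O[C@H]1COCC[C@@H]1OP(=O)(O)OC[C@H](N)C(=O)O` is again the same molecule on paper, but two ring stereocentres are redrawn (the two compounds have the same atoms and bonds; at least one stereo element is drawn with a configuration in one of them and without one in the other: 2 of 4 stereo elements differ; a stereocentre at a saturated ring carbon is drawn R in compound 2 and S in compound 3; a stereocentre at a saturated ring carbon is drawn R in compound 2 and S in compound 3). Within the data shown here, the only measured step that bears on such a redrawing is the one from compound 1 to compound 2, which stayed within the scatter, so no shift beyond the scatter is expected here either, in either direction. The expected step is therefore a number 1.4 percentage points lower from compound 2 to compound 3 (within the scatter), and compound 3 is estimated to reach 10% in this assay, within a range from 3% to 18%.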

Compound 3, largest response reached (Emax), in percent of the reference or control that the assay uses: 12.4%
For compound 3 the middle estimate is 2.4 percentage points below the measured one, within the range that was stated.
By their numbers in this assay, from the lowest: compounds 1, 2 and 3 (each within the scatter of the next).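

Across this assay, redrawing two ring stereocentres gives a number 1 percentage points higher from compound 2 to compound 3 (within the scatter), and redrawing one gives a number 3.8 percentage points higher from compound 1 to compound 3 (within the scatter). Taken with the earlier step, these results place all three compounds within the scatter of one another, so the double change separates the compounds no more than a single change does. In this set of three drawn arrangements, the configuration of these ring carbons therefore produces no readable change in maximal response.

The compounds shown leave open whether the remaining pairing of the two ring stereocentres, or a change at the stereocentre of the serine part, would move the response beyond the scatter. They also leave open whether a longer chain in place of the present one, or an amide in place of the ester, would do so.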